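Removing the fluorine from the 5-bromo-2-fluorophenyl arm

The compounds below may be only part of what the source reports. "The series", "measured", "known", "first", "only" and "open" are said of these compounds alone.

Compound 3 `C=CCn1c(=O)/c(=C\c2cc(Br)ccc2F)[nH]c(=O)/c1=C\c1ccccc1OC` gives 5100 nM in a functional assay on K562 cells (Homo sapiens) for cytotoxicity, read by CCK-8 assay, with a stated time of 72 h (a higher number here means a weaker inhibitor, a lower number a stronger inhibitor), the higher of the two numbers the series has so far. Within the data shown here, compound 1 `C=CCn1c(=O)/c(=C\c2cccc(Cl)c2Cl)[nH]c(=O)/c1=C\c1ccccc1OC` gives 900 nM in this assay, and the one measured step, a 5.7-fold higher number from compound 1 to compound 3 (0.75 log units; beyond the scatter), leads to compound 3. Compound 2 `C=CCn1c(=O)/c(=C\c2ccc(Cl)c(Cl)c2)[nH]c(=O)/c1=C\c1ccccc1OC` is reported as "not active" (no number reported) in this assay, without a number.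

Compound 4 `C=CCn1c(=O)/c(=C\c2cccc(Br)c2)[nH]c(=O)/c1=C\c1ccccc1OC` is reached from compound 3 by hydrogen in place of fluoro on an aromatic carbon. Among the measured compounds shown here, no measured step removes a fluoro from this arm; the only step known, from compound 1 to compound 3, swaps the whole aryl substitution pattern and is therefore only an indirect guide. The inactivity of compound 2 shows that the pattern on this arm matters, but gives no direction for the loss of one fluorine. The expected step is accordingly small, a 1.1-fold lower number from compound 3 to compound 4 (0.05 log units; within the scatter), with no direction claimed beyond the scatter. Compound 4 is thus estimated at 4500 nM in this assay, within the range 1500 nM to 14000 nM.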

Compound 4, half-maximal inhibitory concentration: 2400 nM
Compound 4: the middle estimate sits 1.9-fold (0.27 log units) above what was measured, and the stated range covers the measured number.
By their numbers in this assay, from the lowest: compound 1; then compound 4; then compound 3.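

In this assay, among these compounds, a 2.1-fold lower number from compound 3 to compound 4 (0.33 log units; beyond the scatter) is the first step that changes only this position, and it lies beyond the scatter: with hydrogen in place of fluoro, the number is modestly lower. The 3-bromophenyl arm still falls short of the 2,3-dichlorophenyl arm, with a 2.7-fold higher number from compound 1 to compound 4 (0.43 log units; beyond the scatter), so removing the fluoro from this arm does not bring compound 4 level with compound 1. No measurement at hand accounts for either step.

As far as these compounds go, whether a chloro, a methoxy or an amine at this position would give a lower or a higher number than hydrogen or fluoro remains open. From the compounds shown here alone, it is also open whether the step seen here carries over to an arm with another halogen, such as a 3-chlorophenyl arm.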